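A few compounds are considered here, and "the series" means these few. Any claim that something is new, unique, unknown or untested is made for them only; others in the source may bear on it.

Measured compounds:
Compound 1, `O=C(O)Cn1c(SCc2ccc(Cl)cc2)nc2ccccc21`: 160 nM
Compound 2, `O=C(O)Cn1c(SCc2cccc(Cl)c2)nc2ccccc21`: 186 nM
Compound 3, `Cc1ccc(CSc2nc3ccccc3n2CC(=O)O)cc1`: 220 nM

In an assay on HEK293 cells for displacement of a labelled ligand from prostaglandin D2 receptor 2 (Homo sapiens) (a lower number here means a stronger inhibitor, a higher number a weaker inhibitor), compound 2 gives 186 nM, a number lying between those of compound 1 and compound 3; the step of a 1.2-fold higher number from compound 1 to compound 2 (0.07 log units; within the scatter) and the step of a 1.2-fold higher number from compound 2 to compound 3 (0.07 log units; within the scatter) are both inside the scatter, so the three compounds are not separated by this assay. Compound 4, `O=C(O)Cn1c(SCc2ccc(Cl)c(Cl)c2)nc2ccccc21`, differs from compound 2 by chloro in place of hydrogen on an aromatic carbon; the new chloro sits on an aromatic carbon of a six-membered aromatic ring of carbon only, ortho to a chloro group and para to a large group. Among the measured compounds shown here, two measured steps bear on changes at this ring: a 1.2-fold higher number from compound 1 to compound 2 (0.07 log units; within the scatter), which moves the chloro, and a 1.4-fold higher number from compound 1 to compound 3 (0.14 log units; within the scatter), which swaps chloro for methyl; neither leaves the scatter. For the measured compounds named here, no measured pair adds a second substituent to the ring, so the expectation rests on the small size of these steps. Compound 4 is therefore expected to give 170 nM in this assay, within 80 nM to 360 nM, an estimated step of a 1.1-fold lower number from compound 2 to compound 4 (0.04 log units; within the scatter), not beyond the scatter.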

Compound 4, half-maximal inhibitory concentration: 380 nM
Compound 4: middle estimate off by 2.2-fold (0.35 log units), on the low side, outside the stated range (above it).
By their numbers in this assay, from the lowest: compounds 1, 2, 3 and 4 (each within the scatter of the next, the first and the last beyond it).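

In this assay, among the compounds shown here, adding a second chloro to the ring, ortho to a chloro group and para to a large group, gives the first change on this ring that leaves the scatter: a 2.0-fold higher number from compound 2 to compound 4 (0.31 log units; beyond the scatter), and a 2.4-fold higher number from compound 1 to compound 4 (0.38 log units; beyond the scatter). Moving the single chloro or replacing it with methyl had not separated the compounds, so these data show that the ring's substitution can affect the number, though the steps are modest and rest on compound 4 alone. Nothing available explains this rise.

As far as these compounds go, it remains open whether the rise is specific to chloro or would also follow from a fluoro or methoxy group on the same aromatic carbon. The compounds shown also leave open whether a second substituent elsewhere on the ring would give a similar step.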